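Amide side-chain variation on a shared core: acid analogue

The source may report more compounds than this note shows. Statements on the series, on what has been measured and on what is new or still open speak of the compounds shown alone.

Measured so far:
compound 1, `CCn1c(C(=O)N[C@@H](C)C(=O)OC)ccc1C(CC)(CC)c1ccc(OCS(=O)(=O)c2ccccc2)c(C)c1`: 43700 nM
compound 2, `CCn1c(C(=O)NCC(=O)OC)ccc1C(CC)(CC)c1ccc(OCS(=O)(=O)c2ccccc2)c(C)c1`: > 50000 nM
compound 3, `CCn1c(C(=O)N[C@H](CO)CCO)ccc1C(CC)(CC)c1ccc(OCS(=O)(=O)c2ccccc2)c(C)c1`: 28500 nM

In a functional assay on MCF7 cells (Homo sapiens) for antiproliferative activity, read by MTT assay, with a stated time of 24 h (on this read-out higher numbers stand for weaker inhibition and lower numbers for stronger inhibition), compound 2 gives only a limit, > 50000 nM, so its place among the three is known only as one of the weakest shown; this sits at the limit of > 50000 nM in this assay, at which 1 of the 3 values shown sits. Compound 4, `CCn1c(C(=O)N[C@@H](C)C(=O)O)ccc1C(CC)(CC)c1ccc(OCS(=O)(=O)c2ccccc2)c(C)c1`, differs from compound 2 by 1-carboxyethyl in place of (methoxycarbonyl)methyl on an amide-type nitrogen. Among the measured compounds shown here, the only measured step that touches this change is an at least 1.1-fold higher number from compound 1 to compound 2 (0.05 log units; that floor lies within the scatter), which removes the methyl on the chain carbon and stays within the scatter. For the measured compounds named here, the ester-to-acid part of the change has no measured counterpart. The step from compound 2 to compound 4 in this assay is therefore expected to be a number no higher from compound 2 to compound 4 (the limit leaves the size open), with nothing beyond the scatter. Compound 4 is estimated at 50000 nM, in the range 20000 nM to 150000 nM.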

Compound 4, half-maximal inhibitory concentration: 35500 nM
Compound 4: the middle estimate sits 1.4-fold (0.15 log units) above what was measured; the range from low to high includes it.
By their numbers in this assay, from the lowest: compounds 3, 4 and 1 (each within the scatter of the next). At a limit, above all of these: compound 2.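

In this assay, replacing methyl with hydrogen on the ester oxygen gives a 1.2-fold lower number from compound 1 to compound 4 (0.09 log units; within the scatter), so this change at the amide-type nitrogen does not separate the ester from the acid. The 1-carboxyethyl and 3-hydroxy-1-(hydroxymethyl)propyl groups also remain indistinguishable: a 1.2-fold higher number from compound 3 to compound 4 (0.10 log units; within the scatter). Compound 2 gives only a limit, so its step is a floor, an at least 1.4-fold lower number from compound 2 to compound 4 (0.14 log units; that floor lies within the scatter).

Still open, from the compounds shown here alone, is whether a carboxymethyl group, which lacks the chain methyl, differs from 1-carboxyethyl. Also open, going by these compounds, is whether an amine or a longer chain on this nitrogen gives a number beyond the scatter.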